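The source may report more compounds than this note shows. Statements on the series, on what has been measured and on what is new or still open speak of the compounds shown alone.

Measured so far in a functional assay on L1210 cells (Mus musculus); a lower number here means a stronger inhibitor, a higher number a weaker inhibitor:

Compound 1 `CCCCCCCCc1cn([C@H]2C[C@H](O)[C@@H](CO)O2)c(=O)[nH]c1=O` gives 72 ug/mL.
Compound 2 `CCCCc1cn([C@H]2C[C@H](O)[C@@H](CO)O2)c(=O)[nH]c1=O` reaches only a limit of the assay, > 500 ug/mL.
Compound 3 `CCCCCc1cn([C@H]2C[C@H](O)[C@@H](CO)O2)c(=O)[nH]c1=O` gives 477 ug/mL.

Of the two actual numbers, compound 3 holds the higher one; its nearest neighbour is compound 1, with a 6.6-fold higher number from compound 1 to compound 3 (0.82 log units; beyond the scatter). Compound 2 gives only a limit, and the step of an at least 6.9-fold higher number from compound 1 to compound 2 (0.84 log units; beyond the scatter) is therefore bounded by the limit of > 500 ug/mL in this assay, at which 1 of the 3 values shown sits. Between compound 2 and compound 3 the step is an at least 1.0-fold lower number from compound 2 to compound 3 (0.02 log units; that floor lies within the scatter), so these two cannot be told apart.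

Compound 4 `CCCc1cn([C@H]2C[C@H](O)[C@@H](CO)O2)c(=O)[nH]c1=O` differs from compound 3 in one place: hydrogen in place of ethyl on a saturated chain carbon, three bonds along the chain from an aromatic carbon. The two steps that bear on this are the shortenings of the chain from compound 1, an at least 6.9-fold higher number from compound 1 to compound 2 (0.84 log units; beyond the scatter) and a 6.6-fold higher number from compound 1 to compound 3 (0.82 log units; beyond the scatter), both of which raised the number well beyond the scatter; the shortening from compound 3 to compound 2 showed nothing beyond the scatter, with compound 2 at the limit. Shortening the chain further in compound 4 is therefore expected to keep the number at or above the level of compound 3, and most likely at the limit of this assay.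

Compound 4 is expected to give about 700 ug/mL, in the range 300 ug/mL to 2000 ug/mL. For compound 4 this expectation amounts to a step of a 1.5-fold higher number from compound 3 to compound 4 (0.17 log units; within the scatter).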

Compound 4, concentration for 50% inhibition: > 500 ug/mL
Compound 4 was reported as a limit; the forecaster's own chance of this, stated with the estimate: 75%; the middle value does not contradict the limit.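

In this assay compound 4 gives > 500 ug/mL, which is a limit of the assay and not a number. Putting hydrogen in place of ethyl, three bonds along the chain from an aromatic carbon, gives an at least 1.0-fold higher number from compound 3 to compound 4 (0.02 log units; that floor lies within the scatter), so shortening pentyl to propyl produces no readable change, while the octyl chain of compound 1 remains clearly apart in an at least 6.9-fold higher number from compound 1 to compound 4 (0.84 log units; beyond the scatter). The step between compound 2 and compound 4 joins two limits and cannot be read, so the propyl, butyl and pentyl chains fall into no order, and the short end of the series now rests largely on a ceiling: the limit of > 500 ug/mL in this assay, at which 2 of the 4 values shown sit.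

The compounds shown leave open where between pentyl and octyl the number starts to fall, and whether a hexyl or heptyl chain would already give most of that gain. They also cannot tell whether a longer chain, such as decyl, would lower the number further, or whether an amine or a carboxylic acid at the end of the octyl chain would keep its advantage.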